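Replacing the aminophenyl arm with a piperidine ring

A few compounds are considered here, and "the series" means these few. Any claim that something is new, unique, unknown or untested is made for them only; others in the source may bear on it.

Measured so far:
compound 1, `Nc1cccc(CNc2cc(C(F)(F)F)cc3[nH]ncc23)c1`, 55%
compound 2, `O=C(O)CNc1cccc(CNc2cc(C(F)(F)F)cc3[nH]ncc23)c1`, 8%
compound 3, `OC1CCCC(Nc2cccc(CNc3cc(C(F)(F)F)cc4[nH]ncc34)c2)C1`, 2%

In an assay for inhibition of Indoleamine 2,3-dioxygenase 1 (Homo sapiens), with stated times of 10 min and 60 min, tested at 100 uM (a lower number here means a weaker effect, a higher number a stronger effect of the compound at the concentration tested), compound 1 gives the highest of the three numbers. Compound 2 sits a number 47 percentage points lower from compound 1 to compound 2 (beyond the scatter), and compound 3 sits a number 53 percentage points lower from compound 1 to compound 3 (beyond the scatter); between compound 2 and compound 3 the step is a number 6 percentage points lower from compound 2 to compound 3 (within the scatter). Both measured steps thus show that adding a group to the nitrogen on the aromatic ring of compound 1 costs most of the effect.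

Compound 4, `FC(F)(F)c1cc(NC[C@@H]2CCCCN2)c2cn[nH]c2c1`, takes a different route: piperidin-2-yl in place of 3-aminophenyl on a saturated chain carbon bound to a nitrogen on an aromatic ring. Among the compounds with values here, no measured pair changes this position, so the two steps from compound 1 bear on it only indirectly, as evidence that the outer part of compound 1 is sensitive to alteration. Since compound 1 loses almost all of its effect in this assay by a small addition at that end, replacing the whole 3-aminophenyl group is expected to lower the number as well, though how far is uncertain. Compound 4 is therefore estimated to reach 20%, within 0% to 50%, an expected step of a number 35 percentage points lower from compound 1 to compound 4 (beyond the scatter).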

Compound 4, a percentage reported as inhibition, at one concentration (the size of the read-out at that concentration, not a potency): 81%
Estimate against measurement, compound 4: 61 percentage points below; the whole stated range lies below it.
By their numbers in this assay, from the lowest: compounds 3 and 2 (each within the scatter of the next); then compound 1; then compound 4.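

In this assay the exchange of 3-aminophenyl for piperidin-2-yl on the saturated chain carbon gives a number 26 percentage points higher from compound 1 to compound 4 (beyond the scatter) and so shows that the six-membered aromatic ring of carbon only is not needed for the effect at this position. The earlier steps shown here (a number 47 percentage points lower from compound 1 to compound 2 (beyond the scatter) and a number 53 percentage points lower from compound 1 to compound 3 (beyond the scatter)) placed carboxymethyl or 3-hydroxycyclohexyl on the nitrogen of the 3-aminophenyl group, and compound 4 shows that the loss seen there does not extend to replacement of the whole group. No measurement of any property of these groups accompanies this result, and the data offer no explanation for the rise.

The compounds shown leave open whether the opposite arrangement at the defined stereocentre of piperidin-2-yl, a smaller pyrrolidin-2-yl ring or an open-chain amine would hold the effect at this position. They also leave open whether carboxymethyl on the ring nitrogen of piperidin-2-yl would cost as much as it does on the nitrogen of compound 1, and, as the read-out comes from one concentration, how the potencies of compound 1 and compound 4 compare.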